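Working notes on a four-compound antiproliferative series

The source may report more compounds than this note shows. Statements on the series, on what has been measured and on what is new or still open speak of the compounds shown alone.

Measured so far, in a functional assay on A549 cells (Homo sapiens) for antiproliferative activity, read by sulforhodamine B assay, with a stated time of 48 h; a higher number here means a weaker inhibitor, a lower number a stronger inhibitor:
compound 1 `COc1ccc(C=C(C(=O)/C=C/c2cccc(OC)c2OC)C(=O)/C=C/c2cccc(OC)c2OC)cc1OC`: 170 nM
compound 2 `COc1cccc(/C=C/C(=O)C(=Cc2ccc(O)c(F)c2)C(=O)/C=C/c2cccc(OC)c2OC)c1OC`: 200 nM
compound 3 `COc1ccc(OC)c(/C=C/C(=O)C(=Cc2ccc(OC)c(OC)c2)C(=O)/C=C/c2cc(OC)ccc2OC)c1`: 400 nM

Compound 1 and compound 2 share one core. The change from compound 1 to compound 2 is 3-fluoro-4-hydroxyphenyl in place of 3,4-dimethoxyphenyl on a double-bonded chain carbon bound to a double-bonded chain carbon, and it gave a 1.2-fold higher number from compound 1 to compound 2 (0.07 log units; within the scatter).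

Compound 3 carries a second core built from the same atoms as compound 1, joined differently; the difference between the two cores is not broken down here. In this assay compound 3 gives the highest of the three numbers, and its gap to compound 1 lies beyond the scatter, while its gap to compound 2 lies within it.

Compound 4 `COc1ccc(OC)c(/C=C/C(=O)C(=Cc2ccc(O)c(F)c2)C(=O)/C=C/c2cc(OC)ccc2OC)c1` is not yet measured. Its difference from compound 3 is 3-fluoro-4-hydroxyphenyl in place of 3,4-dimethoxyphenyl on a double-bonded chain carbon bound to a double-bonded chain carbon, the same change that was made from compound 1 to compound 2, at the same place. Among the compounds with values here, the single earlier instance of this change, from compound 1 to compound 2, stayed within the scatter, so on the second core the step is expected to be of similar size: a 1.1-fold higher number from compound 3 to compound 4 (0.05 log units; within the scatter). This rests on the one measured step only; whether the second core responds in the same way is not shown by anything else here.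

For compound 4 the expected value in this assay is 450 nM, with the estimate spanning 200 nM to 1000 nM.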

Compound 4, half-maximal inhibitory concentration: 220 nM
Beside the measured number, compound 4's estimate is 2.0-fold (0.31 log units) above it; low and high end bracket the measured number.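

In this assay the exchange of 3,4-dimethoxyphenyl for 3-fluoro-4-hydroxyphenyl gave a 1.8-fold lower number from compound 3 to compound 4 (0.26 log units; within the scatter) on the core of compound 3. Set beside the earlier instance, the two steps do not differ, so across these two cores the change carries over as a step that stays within the scatter: the same change on two cores in this assay, a 1.2-fold higher number (0.07 log units; within the scatter) from compound 1 to compound 2 and a 1.8-fold lower number (0.26 log units; within the scatter) from compound 3 to compound 4, 2.1-fold (0.33 log units) apart, within the scatter of two such steps
This rests on two steps only, and it does not show that the change is without effect on either core, that the two cores respond identically, or that the same would hold on any further core; the opposite signs of the two steps carry no meaning at this size, and a true difference smaller than the scatter could not be seen in these numbers.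

The compounds shown leave open which part of the entering group matters, since the fluorine and the hydroxyl always arrive together, and a phenyl ring carrying only one of them does not appear here. Also open, going by these compounds, is how either core would take a group of another kind at the same place, such as an amine, a carboxylic acid or a longer chain.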